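This account rests on a few compounds, and the source may have more. Where it says the series, first, only, none or still open, it means among the compounds named here.

Of the compounds shown here, three that share one core have been measured in an assay on CHO cells for displacement of a labelled ligand from adenosine receptor A1 (Homo sapiens), read by scintillation counting, with a stated time of 1 h, tested at 1 uM; a higher number here means more inhibition at the concentration tested (going by the name of the read-out), a lower number less inhibition. Compound 1 `Clc1cccc(-c2cnc(Nc3ccccc3)nc2-c2ccccc2)c1` carries a phenyl on a nitrogen of the core and gives 34%. Compound 2 `C#CCNc1ncc(-c2cccc(Cl)c2)c(-c2ccccc2)n1`, with propargyl in place of phenyl on that nitrogen, gives 76%, and compound 3 `CCCCNc1ncc(-c2cccc(Cl)c2)c(-c2ccccc2)n1`, with butyl in that position, gives 56%. Compound 3 thus stands second highest of the three: the step of a number 20 percentage points lower from compound 2 to compound 3 (beyond the scatter) separates it from compound 2, while the step of a number 22 percentage points higher from compound 1 to compound 3 (beyond the scatter) places it well above compound 1.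

Compound 4 `Clc1cccc(-c2cnc(NCCCc3ccccc3)nc2-c2ccccc2)c1` differs from compound 3 in a single place: phenyl in place of methyl on a saturated chain carbon, three bonds along the chain from a nitrogen on an aromatic ring. Within the data shown here, no measured step adds a phenyl at the far end of a chain, so the closest guidance comes from a number 22 percentage points higher from compound 1 to compound 3 (beyond the scatter) and a number 42 percentage points higher from compound 1 to compound 2 (beyond the scatter), in which a chain in place of a phenyl sitting directly on the nitrogen raised the number. Among the measured compounds shown here, those steps show only that the numbers rise when the phenyl leaves the nitrogen itself; compound 4 keeps the chain and places a phenyl three bonds out, which none of the measured compounds test. A change in this assay of modest size is therefore expected, more likely downward than upward.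

The estimate for compound 4 is 48%, within a range from 25% to 72%. That estimate corresponds to an expected step of a number 8 percentage points lower from compound 3 to compound 4 (within the scatter).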

Compound 4, a percentage reported as inhibition, at one concentration (the size of the read-out at that concentration, not a potency): 33%
For compound 4 the middle estimate is 15 percentage points above the measured one, and the stated range covers the measured number.
By their numbers in this assay, from the lowest: compounds 4 and 1 (each within the scatter of the next); then compound 3; then compound 2.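

In this assay the step of a number 23 percentage points lower from compound 3 to compound 4 (beyond the scatter) shows that this position on the chain is not indifferent to what is placed there: phenyl in place of methyl, three bonds along the chain from the nitrogen, goes with a clearly lower number, so having a chain on the nitrogen does not by itself hold the number up. The step of a number 43 percentage points lower from compound 2 to compound 4 (beyond the scatter) is large, and the step of a number 1 percentage points lower from compound 1 to compound 4 (within the scatter) leaves the two compounds indistinguishable, so the gain seen when a chain replaced the phenyl on the nitrogen is absent once a phenyl sits at the far end of the chain. Nothing available here explains why these numbers differ.

Going by these compounds, whether the aromatic ring itself or the extra length counts for more remains open, and 3-cyclohexylpropyl or a longer plain chain such as hexyl on the same nitrogen would help separate the two. Benzyl and phenethyl would show how the number changes as the phenyl moves closer to the nitrogen, while an amine at the chain end would test a quite different kind of group at this position.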